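Halogenated aryl hydrazone step in the antiproliferative series

The compounds below may be only part of what the source reports. "The series", "measured", "known", "first", "only" and "open" are said of these compounds alone.

- compound 1 `N#Cc1ccc(/C=N/NC(=O)Nc2ccc(Oc3ccnc4[nH]ccc34)c(F)c2)cc1` gives 9030 nM
- compound 2 `O=C(N/N=C/c1ccc([N+](=O)[O-])cc1)Nc1ccc(Oc2ccnc3[nH]ccc23)c(F)c1` gives 150 nM
- compound 3 `O=C(N/N=C/c1ccc(Cl)c(Cl)c1)Nc1ccc(Oc2ccnc3[nH]ccc23)c(F)c1` gives 14100 nM

In a functional assay on PC-3 cells (Homo sapiens) for antiproliferative activity, read by MTT assay, with a stated time of 72 h (on this read-out lower numbers stand for stronger inhibition and higher numbers for weaker inhibition), compound 3 sits at the high end together with compound 1, the gap being a 1.6-fold higher number from compound 1 to compound 3 (0.19 log units; within the scatter) and thus no real difference. Compound 2 stands apart, shown by a 60-fold lower number from compound 1 to compound 2 (1.78 log units; beyond the scatter) and by a 94-fold higher number from compound 2 to compound 3 (1.97 log units; beyond the scatter) in the opposite direction. Compound 4 `O=C(N/N=C/c1ccc(F)cc1Cl)Nc1ccc(Oc2ccnc3[nH]ccc23)c(F)c1` carries 2-chloro-4-fluorophenyl in place of 3,4-dichlorophenyl on a carbon with a double bond to nitrogen. Compound 4 has no nitro group, so the large steps offer little guide, and the small step among the non-nitro compounds is the nearer precedent. An estimated 1.6-fold lower number from compound 3 to compound 4 (0.19 log units; within the scatter) would stay within the scatter in this assay as expected. For compound 4 the estimate is 9000 nM with an expected range of 2000 nM to 30000 nM overall.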

Compound 4, half-maximal inhibitory concentration: 3 nM
The estimate for compound 4 lay 3000-fold (3.48 log units) above the measured number; measured number below the stated range.
By their numbers in this assay, from the lowest: compound 4; then compound 2; then compounds 1 and 3 (each within the scatter of the next).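

In this assay, within the data shown here, the aryl group on the carbon with a double bond to nitrogen has far more range than the earlier compounds showed: 2-chloro-4-fluorophenyl gives a 4700-fold lower number from compound 3 to compound 4 (3.67 log units; beyond the scatter) and a 3000-fold lower number from compound 1 to compound 4 (3.48 log units; beyond the scatter). A halogenated aryl group is therefore not confined to the high end of the series. Nor does a low number here require nitro, with a 50-fold lower number from compound 2 to compound 4 (1.70 log units; beyond the scatter).

The compounds shown leave open whether the fluorine or the placing of the chlorine carries the step, and how an amine or a carboxylic acid would fare on this carbon. Nothing measured here accounts for the gap between the two halogenated aryl groups.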